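Nitro on the six-membered ring of compound 2

This account rests on a few compounds, and the source may have more. Where it says the series, first, only, none or still open, it means among the compounds named here.

In a functional assay on PC-3 cells (Homo sapiens) for inhibition, read by sulforhodamine B assay, with a stated time of 48 h (a lower number here means a stronger inhibitor of growth, a higher number a weaker inhibitor of growth), compound 1 `CC1=CC[C@H](C(C)(C)NC(=S)N/N=C/c2ccco2)CC1` gives 13500 nM. Compound 2 `CC1=CC[C@H](C(C)(C)NC(=S)N/N=C(\C)c2ccccc2)CC1` reaches only a limit, > 100000 nM, in this assay. Among the compounds with values here, because the limit of > 100000 nM in this assay, at which 1 of the 2 values shown sits, is where compound 2 sits, no measured step in this assay sets the size of what follows. Compound 3 `CC1=CC[C@H](C(C)(C)NC(=S)N/N=C(\C)c2ccc([N+](=O)[O-])cc2)CC1` carries nitro in place of hydrogen on an aromatic carbon. With nothing measured to go by, the change is expected to give a small step or none beyond the scatter, with a fair chance of another limit. Compound 3 is expected near 80000 nM, within 20000 nM to 300000 nM. The estimated step is an at least 1.2-fold lower number from compound 2 to compound 3 (0.09 log units; that floor lies within the scatter).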

Compound 3, concentration for 50% growth inhibition: 62600 nM
For compound 3 the middle estimate is 1.3-fold (0.11 log units) above the measured one; measured number inside the range.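

Nitro in place of hydrogen, para to a large group, gives an at least 1.5-fold lower number from compound 2 to compound 3 (0.20 log units; that floor lies within the scatter). Compound 3 therefore reads as a number in this assay, which shows that this place on the ring accepts nitro and still gives a measurable value. The step is only a floor, and its true size stays unknown, because compound 2 stands at a limit: the limit of > 100000 nM in this assay, at which 1 of the 3 values shown sits.

Open, going by these compounds, is whether an amine or a methoxy group at the same place would give a lower number than nitro. Also open, on these data alone, is whether a carboxylic acid there would keep a measurable value.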